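This account rests on a few compounds, and the source may have more. Where it says the series, first, only, none or still open, it means among the compounds named here.

Working notes on the series. Compound 1 `Clc1ccc(Cc2nn3c(Br)c(-c4ccc(Cl)cc4Cl)nc3s2)cc1` gives in a functional assay on HeLa cells (Homo sapiens) for cytotoxicity, with a stated time of 72 h (on this read-out higher numbers stand for weaker inhibition and lower numbers for stronger inhibition), a value of 118000 nM. Compound 3 `O=Cc1c(-c2ccc(Cl)cc2Cl)nc2sc(Cc3ccc(Cl)cc3)nn12` differs from compound 1 by formyl in place of bromo on an aromatic carbon; in this assay compound 3 gives 64000 nM, and the step is a 1.8-fold lower number from compound 1 to compound 3 (0.27 log units; within the scatter). Compound 2 `Clc1ccc(Cc2nn3c(Br)c(-c4ccccc4)nc3s2)cc1` differs from compound 1 by phenyl in place of 2,4-dichlorophenyl on an aromatic carbon. In this assay compound 2 gives only > 250000 nM, which is a limit of the assay and not a number, being (the limit of > 250000 nM in this assay, at which 1 of the 3 values shown sits). The step is an at least 2.1-fold higher number from compound 1 to compound 2 (0.32 log units; beyond the scatter).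

Compound 4 `O=Cc1c(-c2ccccc2)nc2sc(Cc3ccc(Cl)cc3)nn12` has not been measured; it differs from compound 3 by phenyl in place of 2,4-dichlorophenyl on an aromatic carbon. This is the same kind of change as that from compound 1 to compound 2, though not the same: in compound 1 the place is next to the ring atom that bears a bromo group, whereas in compound 3 it is next to the ring atom that bears a formyl group. Since the step of a 1.8-fold lower number from compound 1 to compound 3 (0.27 log units; within the scatter) stayed within the scatter, the change in compound 4 is expected to resemble the earlier one in this assay, the expected step being a 2.7-fold higher number from compound 3 to compound 4 (0.42 log units; beyond the scatter). Compound 4 is thus estimated at 170000 nM, between 80000 nM and 400000 nM, with a real chance that this assay again reports only a limit.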

Compound 4, half-maximal inhibitory concentration: 45000 nM
For compound 4 the middle estimate is 3.8-fold (0.58 log units) above the measured one; the whole stated range lies above it.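

In this assay, phenyl in place of 2,4-dichlorophenyl gives a 1.4-fold lower number from compound 3 to compound 4 (0.15 log units; within the scatter), which does not repeat what the same change did on the core of compound 1: the same change on two cores in this assay, an at least 2.1-fold higher number (0.32 log units; beyond the scatter) from compound 1 to compound 2 and a 1.4-fold lower number (0.15 log units; within the scatter) from compound 3 to compound 4, at least 3.0-fold (0.47 log units) apart, beyond the scatter of two such steps

Formyl in place of bromo gives an at least 5.5-fold lower number from compound 2 to compound 4 (0.74 log units; beyond the scatter), and this step likewise does not match its counterpart on the other core: the same change on two cores in this assay, a 1.8-fold lower number (0.27 log units; within the scatter) from compound 1 to compound 3 and an at least 5.5-fold lower number (0.74 log units; beyond the scatter) from compound 2 to compound 4, at least 3.0-fold (0.47 log units) apart, beyond the scatter of two such steps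

So in this assay neither change can be carried from one core to the other at the same size, but these two pairs do not show the reason or the full size of the gap, since compound 2 rests on a limit of the assay and not a number: the limit of > 250000 nM in this assay, at which 1 of the 4 values shown sits.

On these data alone, it remains open whether phenyl in place of 2,4-dichlorophenyl would follow compound 1 and compound 2 or compound 3 and compound 4 on a core carrying an amine or a carboxylic acid in place of bromo or formyl. A nitrile or a hydroxymethyl group at that place would leave the same question open.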